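Shortening a Linker Where Nothing Inhibits Yet

This account rests on a few compounds, and the source may have more. Where it says the series, first, only, none or still open, it means among the compounds named here.

Compound 1 `CCCc1nc(C)c2cnn(C/C=C/C(=O)OCC)c(=O)n12` was tested in a functional assay for inhibition, with Homo sapiens as the target; a lower number here means a stronger inhibitor, a higher number a weaker inhibitor. For compound 1 this assay reports only a limit, > 48000 nM, not a number. Compound 2 `Cc1ncn2c(Nc3cccs3)nncc12` likewise shows only a limit in this assay, > 48000 nM. What is known so far amounts to the limit of > 48000 nM in this assay, at which 2 of the 2 values shown sit, so compound 1 stands no differently from the other compound. Compound 3 `CCCc1nc(C)c2cnn(CC(=O)OCC)c(=O)n12` differs from compound 1 by ethoxycarbonyl in place of 2-(ethoxycarbonyl)ethenyl on a saturated chain carbon bound to an aromatic nitrogen. For the measured compounds named here, no measured pair shows the effect of such a change, and both known values are limits, so the expected step is a step that the limit leaves unreadable from compound 1 to compound 3, none beyond the scatter. Compound 3 is therefore expected to give 60000 nM, within 20000 nM to 200000 nM, most likely again only as a limit.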

Compound 3, half-maximal inhibitory concentration: > 48000 nM
Compound 3 gave a limit, no number (the forecaster's own chance of this, stated with the estimate: 85%); the middle value lies beyond the limit too.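

For the compounds shown here, compound 1 and compound 3 each give only a limit, not a number, so no step between them can be read: the limit of > 48000 nM in this assay, at which 3 of the 3 values shown sit. The compounds shown leave open which structure, if any, would give a measurable value in this assay.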